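Aryl Variation on the Piperazine Sulfonamide Series

The source may report more compounds than this note shows. Statements on the series, on what has been measured and on what is new or still open speak of the compounds shown alone.

Compound 1, `CCCn1c(=O)[nH]c2nc(-c3ccc(S(=O)(=O)N4CCN(c5ccc(I)cc5)CC4)cc3)[nH]c2c1=O`: 36%
Compound 2, `CCCn1c(=O)[nH]c2nc(-c3ccc(S(=O)(=O)N4CCN(c5ccc(F)cc5)CC4)cc3)[nH]c2c1=O`: 38%

The two compounds were tested in an assay on CHO cells for displacement of a labelled ligand from adenosine receptor A3 (Homo sapiens), read by scintillation counting, with a stated time of 45 min, tested at 1 uM, in the presence of a further agent that is not named here; on this read-out higher numbers stand for more inhibition at the one concentration tested (going by the name of the read-out) and lower numbers for less inhibition. Going by the values given here, compound 2 gives 38%, the higher of the two numbers, but its only neighbour is compound 1 with 36%, and the step of a number 2 percentage points higher from compound 1 to compound 2 (within the scatter) lies within the scatter, so the two cannot be told apart.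

Compound 3, `CCCn1c(=O)[nH]c2nc(-c3ccc(S(=O)(=O)N4CCN(c5ccccc5C)CC4)cc3)[nH]c2c1=O`, has not yet been measured in this assay. It differs from compound 2 in one place: 2-methylphenyl in place of 4-fluorophenyl on an amine nitrogen in a ring.

Among the compounds with values here, the one measured step, fluoro in place of iodo on the same aromatic ring, was a number 2 percentage points higher from compound 1 to compound 2 (within the scatter) and bears only loosely on this change, since no measured pair shows a methyl group or a shift of the substituent around the ring. Compound 3 is therefore expected to stay near compound 2, with the step of a number 4 percentage points lower from compound 2 to compound 3 (within the scatter) not beyond the scatter. The estimate for compound 3 is 34%, within 12% to 56%.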

Compound 3, a percentage reported as inhibition, at one concentration (the size of the read-out at that concentration, not a potency): 25%
For compound 3 the middle estimate is 9 percentage points above the measured one; measured number inside the range.
By their numbers in this assay, from the lowest: compound 3; then compounds 1 and 2 (each within the scatter of the next).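

In this assay, fluoro and iodo on the aromatic ring could not be told apart, but changing the aryl group on this amine nitrogen in a ring does register: a number 13 percentage points lower from compound 2 to compound 3 (beyond the scatter) and a number 11 percentage points lower from compound 1 to compound 3 (beyond the scatter) are both modest drops. With both steps beyond the scatter, compound 3 is the lowest of the three, so this position does not accept every aryl group equally. Nothing available explains the drop.

The change from 4-fluorophenyl to 2-methylphenyl alters both the substituent and its place on the ring, and the compounds shown do not separate these two effects. A 4-methylphenyl or 2-fluorophenyl group would address that question, while an unsubstituted phenyl or a methoxy group would show how far the trend extends.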